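This account rests on a few compounds, and the source may have more. Where it says the series, first, only, none or still open, it means among the compounds named here.

Of the compounds shown here, three have been measured in an assay on isolated protein for inhibition of Rho-associated protein kinase 2 (Homo sapiens), read by scintillation counting, radiometric assay and 33P incorporation, with a stated time of 40 min, in the presence of a further agent that is not named here; on this read-out lower numbers stand for stronger inhibition and higher numbers for weaker inhibition. Compound 1, `CN(C)c1ccc(C(=O)Nc2cccc(NC(=O)COc3ccc4c(c3)NC(=O)CC4)c2)cc1`, gives 3140 nM. Compound 2, `COc1ccc(OCC(=O)Nc2cccc(NC(=O)c3ccc(N(C)C)cc3)c2)cc1OC`, gives only > 10000 nM, which is a limit of the assay rather than a number. Compound 3, `O=C(COc1ccc2c(=O)ccoc2c1)Nc1cccc(NC(=O)c2ccccc2)c1`, gives 16 nM, the lowest of the two real numbers; compound 1 is the nearest, and the gap between them lies beyond the scatter.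

Among the compounds with values here, the one step measured between single-point neighbours swaps the ring system on the oxygen on a saturated carbon, and it reads an at least 3.1-fold higher number from compound 1 to compound 2 (0.50 log units; beyond the scatter), the end point being (the limit of > 10000 nM in this assay, at which 1 of the 3 values shown sits). That step changes the opposite end of the shared core from the one touched here and so says little about the move to compound 4.

Compound 4 is `CC(C)(C)c1ccc(C(=O)Nc2cccc(NC(=O)COc3ccc4c(=O)ccoc4c3)c2)cc1`. Its difference from compound 3 is tert-butyl in place of hydrogen on an aromatic carbon, placing a tert-butyl on an aromatic carbon of a six-membered aromatic ring of carbon only, para to a large group. Within the data shown here, no measured step touches that ring, so the expectation rests on the potency of compound 3 alone, with a step of a 1.3-fold higher number from compound 3 to compound 4 (0.10 log units; within the scatter) expected, which is none beyond the scatter. Compound 4 is therefore expected to give about 20 nM in this assay, within a range from 5 nM to 80 nM.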

Compound 4, half-maximal inhibitory concentration: 34 nM
Beside the measured number, compound 4's estimate is 1.7-fold (0.23 log units) below it; the range from low to high includes it.
By their numbers in this assay, from the lowest: compound 3; then compound 4; then compound 1. At a limit, above all of these: compound 2.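

Within the data shown here, until now no measured step touched the six-membered aromatic ring of carbon only, and replacing hydrogen with tert-butyl on one of its aromatic carbons, para to a large group, gives the first reading there in this assay, with a 2.1-fold higher number from compound 3 to compound 4 (0.33 log units; beyond the scatter). The step is modest but lies beyond the scatter, so this position accepts the 4 added heavy atoms of tert-butyl with a small loss of inhibition, and compound 4 still gives 34 nM. No measurement shown bears on the reason for this rise.

On these data alone, one added group at one place cannot show how the number responds to other groups there, such as a carboxylic acid, a primary amine or a shorter carbon chain like methyl, so it remains open whether any of these would match or improve on hydrogen. As far as these compounds go, compound 1 and compound 2 also carry a group on a ring of this kind, but each differs from compound 3 in more than one place, so what that group does on the core of compound 3 also stays open.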